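Replacing the propylsulfonyl group with an oxazole ring

The source may hold more compounds than are shown below. What is called first, only, known or untested is meant among the compounds shown, and "the series" means these compounds.

Of the compounds shown here, three sharing one core have been measured in an in vivo ADME assay on the whole organism (plasma) for pharmacokinetics, with Rattus norvegicus as the target, at a dose of 50 mg/kg by the oral route; a higher number here means more compound in the circulation at the dose given, a lower number less compound in the circulation. Compound 1 `Cc1cc(C)c(NC(=O)c2sccc2S(=O)(=O)Nc2onc(C)c2Cl)c(C)c1` gives 81600 nM, compound 2 `Cc1cc(C)c(NC(=O)c2sccc2S(=O)(=O)Nc2onc(C)c2Cl)c(Cl)c1` gives 103000 nM, and compound 3 `CCCS(=O)(=O)c1cc(C)cc(C)c1NC(=O)c1sccc1S(=O)(=O)Nc1onc(C)c1Cl` gives 5450 nM, the lowest of the three. The steps were a 1.3-fold higher number from compound 1 to compound 2 (0.10 log units; within the scatter), a 15-fold lower number from compound 1 to compound 3 (1.18 log units; beyond the scatter) and a 19-fold lower number from compound 2 to compound 3 (1.28 log units; beyond the scatter). Compound 4 `Cc1cc(C)c(NC(=O)c2sccc2S(=O)(=O)Nc2onc(C)c2Cl)c(-c2ncco2)c1` is not yet measured; it differs from compound 3 by 1,3-oxazol-2-yl in place of propylsulfonyl on an aromatic carbon. Going by the values given here, both large steps removed or introduced propylsulfonyl at this position, so replacing it is expected to move the number upward again, though the oxazole has no precedent here and the rise is expected to be partial. The expected step is a 3.7-fold higher number from compound 3 to compound 4 (0.56 log units; beyond the scatter). Compound 4 is therefore estimated at 20000 nM, within a range from 5000 nM to 80000 nM.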

Compound 4, maximal plasma concentration: 134000 nM
Estimate against measurement, compound 4: 6.7-fold (0.83 log units) below; measured number above the stated range.
By their numbers in this assay, from the lowest: compound 3; then compounds 1, 2 and 4 (each within the scatter of the next).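

In this assay, 1,3-oxazol-2-yl in place of propylsulfonyl gives a 25-fold higher number from compound 3 to compound 4 (1.39 log units; beyond the scatter), so the low number does not follow from any large group at this position. The other two steps are a 1.3-fold higher number from compound 2 to compound 4 (0.11 log units; within the scatter) and a 1.6-fold higher number from compound 1 to compound 4 (0.22 log units; within the scatter), which puts the oxazole level with methyl and chloro and leaves propylsulfonyl alone in giving a low number. The two groups exchanged have the same counted hydrogen-bond acceptors and donors, so those counts do not separate them.

Nothing measured here explains the difference between these groups. On these data alone, it remains open whether methylsulfonyl, a sulfonamide or an amine at this position would also give a low number.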